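Chloro for methoxy on the compound 1 scaffold

This account rests on a few compounds, and the source may have more. Where it says the series, first, only, none or still open, it means among the compounds named here.

Measured in a functional assay on A549 cells (Homo sapiens) for antiproliferative activity, read by MTT assay, with a stated time of 48 h; on this read-out lower numbers stand for stronger inhibition and higher numbers for weaker inhibition:
- compound 1 `COc1ccc(/C=C/C(=O)Nc2cc(-c3ccc(Br)cc3)[nH]n2)cc1`: 820 nM
- compound 2 `Cc1ccc(-c2cc(NC(=O)/C=C/c3ccc(C(F)(F)F)cc3)n[nH]2)cc1`: 1020 nM
- compound 3 `O=C(/C=C\c1ccc(C(F)(F)F)cc1)Nc1cc(-c2ccccc2)[nH]n1`: 880 nM

Compound 1 at 820 nM stands within the scatter of both other compounds, so the three values do not separate. Among the measured compounds shown here, these compounds differ from one another in more than one place, and no single-change step is available to calibrate the next one.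

Compound 4 `O=C(/C=C/c1ccc(Cl)cc1)Nc1cc(-c2ccc(Br)cc2)[nH]n1` keeps the rest of compound 1 and changes one place: chloro in place of methoxy on an aromatic carbon, para to a large group, reading 4-methoxyphenyl to 4-chlorophenyl (chloro in place of methoxy on an aromatic carbon).

For the measured compounds named here, the only guide is the narrow spread of values. Compound 1 carries methoxy and gives 820 nM, while compound 3 carries trifluoromethyl and gives 880 nM. No step beyond the scatter is expected in this assay, and no direction can be assigned. The expected change is a 1.0-fold lower number from compound 1 to compound 4 (0.01 log units; within the scatter). The estimate for compound 4 is 800 nM, with an expected range from 400 nM to 1600 nM.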

Compound 4, half-maximal inhibitory concentration: 1210 nM
Beside the measured number, compound 4's estimate is 1.5-fold (0.18 log units) below it; the measured number falls inside the stated range.
By their numbers in this assay, from the lowest: compounds 1, 3, 2 and 4 (each within the scatter of the next).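

In this assay, the series now has its first single-change step, which reads a 1.5-fold higher number from compound 1 to compound 4 (0.17 log units; within the scatter). On an aromatic carbon para to a large group, the 4-methoxyphenyl to 4-chlorophenyl exchange therefore gives no separable change in the read-out, even though methoxy counts a hydrogen-bond acceptor and chloro counts none. No measurement at hand bears on why the two groups read alike.

Going by these compounds, whether an amine or a carboxylic acid at this position would give a step beyond the scatter remains open. On these data alone, it is also open whether chloro in place of methoxy would read the same on a compound whose 4-bromophenyl group is replaced, for example by an unsubstituted phenyl.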